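Lengthening an Ether Chain on a Eugenol-Derived Core

The source may hold more compounds than are shown below. What is called first, only, known or untested is meant among the compounds shown, and "the series" means these compounds.

Measured compounds:
compound 1 `C=CCc1cc(OC)c(OC(C)C(O[C@@H]2C[C@H](C)CC[C@H]2C(C)C)c2ccc(O)c(OC)c2)c(OC)c1` with 28 nM
compound 2 `C=CCc1cc(OC)c(OC(C)C(OC)c2ccc(O)c(OC)c2)c(OC)c1` with 3450 nM

Both compounds were tested in an assay on HEK293 cells for agonist activity at transient receptor potential cation channel subfamily M member 8 (Homo sapiens), read by fluorescence and calcium flux, with a stated time of 5 min; a lower number here means that less compound is needed, a higher number that more compound is needed for the effect. Compound 2 stands at the higher of the two numbers, and its nearest neighbour is compound 1, which differs only at the oxygen on a saturated carbon: the step of a 120-fold higher number from compound 1 to compound 2 (2.09 log units; beyond the scatter) shows that replacing the 2-isopropyl-5-methylcyclohexyl group by methyl raises the number by a large margin, well beyond the usual scatter.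

Compound 3 `C=CCc1cc(OC)c(OC(C)C(OCCCCCC)c2ccc(O)c(OC)c2)c(OC)c1` has not yet been measured. It differs from compound 2 in one place: pentyl in place of hydrogen on a saturated chain carbon bound to an oxygen on a saturated carbon. Put another way, the methoxy of compound 2 becomes a hexyloxy. Within the data shown here, the only step that bears on this change is the one from compound 1 to compound 2, where a bulkier group on this same oxygen went with a far lower number. Hexyl is larger than methyl but not the same group as the cyclohexyl substituent, so a move in the same direction, though smaller, is expected: compound 3 is estimated at 400 nM, within 80 nM to 2000 nM, meaning an expected step of an 8.6-fold lower number from compound 2 to compound 3 (0.94 log units; beyond the scatter).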

Compound 3, half-maximal effective concentration: 329 nM
Compound 3: the middle estimate sits 1.2-fold (0.08 log units) above what was measured, and the stated range covers the measured number.
By their numbers in this assay, from the lowest: compound 1; then compound 3; then compound 2.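

In this assay the change from methoxy to hexyloxy gives a 10-fold lower number from compound 2 to compound 3 (1.02 log units; beyond the scatter) and so shows that a plain open chain on this oxygen, with no ring in it, is enough to lower the number by a large step. Hexyl still does not match the 2-isopropyl-5-methylcyclohexyl group, since putting hexyl in its place gives a 12-fold higher number from compound 1 to compound 3 (1.07 log units; beyond the scatter) and the chain therefore closes only part of the gap left by methyl. Nothing measured here explains either step.

With methyl and hexyl as the only open chains on this oxygen, it remains unclear whether the number falls steadily as the chain grows, or whether it reaches a lowest point somewhere along the way, and propyl or a longer chain such as octyl would help to tell these apart. On these data alone, it also remains open whether a ring itself matters, which a plain cyclohexyl group on this oxygen could test, and how a hexyl chain ending in an amine or a carboxylic acid would compare.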